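Piperidine for morpholine on the thiocarbonyl of compound 1

The source may report more compounds than this note shows. Statements on the series, on what has been measured and on what is new or still open speak of the compounds shown alone.

Measured so far in a functional assay on A-431 cells (Homo sapiens) for cytotoxicity, read by MTT assay, with a stated time of 72 h, tested at 30 uM; on this read-out higher numbers stand for more inhibition of growth at the one concentration tested and lower numbers for less inhibition of growth:
compound 1 `N/C(=N\NC(=S)N1CCOCC1)c1ccccn1` gives 78.8%
compound 2 `Cc1ccnc(/C(N)=N/NC(=S)N2CCOCC2)c1` gives 74.6%
compound 3 `N/C(=N\NC(=S)N1CCCC1)c1ccc(F)cn1` gives 83.3%

For the measured compounds named here, compound 1 stands second of the three numbers, yet its neighbours on either side lie within the scatter of it: the one measured step, a number 4.2 percentage points lower from compound 1 to compound 2 (within the scatter), is within the scatter, and compound 3, which differs from compound 1 in two places at once, gives a value whose gap to compound 1 is also within the scatter. On these three compounds, then, nothing has yet moved the read-out beyond its noise.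

Compound 4 `N/C(=N\NC(=S)N1CCCCC1)c1ccccn1` takes the step (piperidin-1-yl in place of morpholin-4-yl on a thiocarbonyl carbon). Going by the values given here, no measured pair changes the amine on the thiocarbonyl carbon alone; compound 3 carries a pyrrolidinyl there but also a fluorine on the core, so its value cannot be split between the two changes. Among the compounds with values here, the only clean step, from compound 1 to compound 2, touched the core and stayed within the scatter.

With nothing pointing either way, compound 4 is expected to stay close to compound 1, with a step of a number 1.2 percentage points higher from compound 1 to compound 4 (within the scatter). The estimate for compound 4 is 80%, expected to lie between 68% and 90%.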

Compound 4, percent growth inhibition at one concentration: 79.7%
Compound 4: the middle estimate sits 0.3 percentage points above what was measured, and the stated range covers the measured number.
By their numbers in this assay, from the lowest: compounds 2, 1, 4 and 3 (each within the scatter of the next).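

In this assay, for the compounds shown here, the step at this position is a number 0.9 percentage points higher from compound 1 to compound 4 (within the scatter), the first measured change that touches only the amine on the thiocarbonyl carbon while the shared core stays the same. Piperidin-1-yl takes the place of morpholin-4-yl there, so the ring oxygen and the hydrogen-bond acceptor counted on morpholin-4-yl both go, and at the one concentration tested the read-out does not move beyond its usual scatter. Nothing measured on these compounds accounts for this result.

The compounds shown leave open whether a ring with a second nitrogen, such as piperazin-1-yl, or an open-chain amine, such as diethylamino, on the thiocarbonyl carbon would shift the read-out beyond its scatter. They also leave open what the pyrrolidinyl group does on the core of compound 1 with no fluorine present, as in compound 3 that group and the fluorine cannot be read apart.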